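Extending the amine-bearing chain by two carbons

The compounds below may be only part of what the source reports. "The series", "measured", "known", "first", "only" and "open" are said of these compounds alone.

Compound 1, `COc1cc(/C=C/C(=O)Nc2ccccc2)ccc1OCCCN(C)C`: 1.55
Compound 2, `COc1cc(/C=C/C(=O)Nc2ccccc2)ccc1OCCCCN(C)C`: 1.57

In a physicochemical assay for lipophilicity, using the shake flask method, measured as octanol-water partition, at pH 7.4 (a higher number here means a more lipophilic compound, a lower number a more polar compound), compound 1 stands lowest of the two numbers measured, with compound 2 nearest, though the two lie within the scatter of each other. Compound 3 is `COc1cc(/C=C/C(=O)Nc2ccccc2)ccc1OCCCCCN(C)C`. Relative to compound 1 it carries 2-(dimethylamino)ethyl in place of dimethylamino on a saturated chain carbon, three bonds along the chain from an oxygen on an aromatic ring. Among the measured compounds shown here, the one comparable step, a number 0.02 log units higher from compound 1 to compound 2 (within the scatter), was flat. A longer chain here is therefore expected to raise this assay only modestly, giving an estimated a number 0.35 log units higher from compound 1 to compound 3 (beyond the scatter). Compound 3 is expected at about 1.9, between 1.5 and 2.3.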

Compound 3, partition coefficient: 1.61
Compound 3: the middle estimate sits 0.29 log units above what was measured; the range from low to high includes it.
By their numbers in this assay, from the lowest: compounds 1, 2 and 3 (each within the scatter of the next).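

In this assay, the longer chain of compound 3 gives a number 0.06 log units higher from compound 1 to compound 3 (within the scatter), and the one further carbon gives a number 0.04 log units higher from compound 2 to compound 3 (within the scatter), so a 2-(dimethylamino)ethyl group in this place reads no differently from dimethylamino. The flat result thus holds for a two-carbon extension as well as for a single carbon, and none of the three compounds goes against it. Nothing available explains this flat result.

Still open, on these data alone, is whether a longer chain, or piperidine or a carboxylic acid in place of dimethylamino, would also leave this assay unchanged.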